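A hydroxy group on the chain of compound 1

The compounds below may be only part of what the source reports. "The series", "measured", "known", "first", "only" and "open" are said of these compounds alone.

In an assay on HEK293 cells for displacement of a labelled ligand from D(4) dopamine receptor (Homo sapiens), read by scintillation counting, with a stated time of 1 h (on this read-out lower numbers stand for stronger inhibition and higher numbers for weaker inhibition), compound 1 `Clc1cccc(N2CCN(CCCCn3cc(-c4ccc(-c5ccccc5)cc4)nn3)CC2)c1Cl` gives > 10000 nM, which is a limit of the assay and not a number. Compound 1 therefore sits at the limit of > 10000 nM in this assay, at which 1 of the 3 values shown sits, the weakest reading that this assay reports.

Two further compounds carry a hydroxy group on their chain. In this assay compound 2 `COc1ccccc1N1CCN(CC(O)CCn2cc(-c3ccc4ncccc4c3)nn2)CC1` gives > 3000 nM, again a limit and not a number. In this assay compound 3 `COc1ccccc1-c1cn(CCC(O)CN2CCN(c3ccccc3OC)CC2)nn1` gives > 3000 nM, also a limit. For the measured compounds named here, both sit at the limit of > 3000 nM in this assay, at which 2 of the 3 values shown sit, and the single step between them, a step that the two limits leave unreadable from compound 2 to compound 3, cannot be read because the limit of > 3000 nM in this assay, at which 2 of the 3 values shown sit, caps both ends.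

Compound 4 `OC(CCn1cc(-c2ccc(-c3ccccc3)cc2)nn1)CN1CCN(c2cccc(Cl)c2Cl)CC1` differs from compound 1 by hydroxy in place of hydrogen on a saturated chain carbon bound to two saturated chain carbons. Going by the values given here, no measured step isolates this change; the only bearing comes from compound 2 and compound 3, which carry a hydroxy group at the same kind of chain position and still sit at the limit of > 3000 nM in this assay, at which 2 of the 3 values shown sit, and from compound 1 itself at the limit of > 10000 nM in this assay, at which 1 of the 3 values shown sits. A step beyond the scatter in either direction cannot be inferred, and the step that the limit leaves unreadable from compound 1 to compound 4 is expected to stay unreadable at a limit. Compound 4 is therefore estimated at 15000 nM, with a range from 3000 nM to 60000 nM, and most probably reported only as a limit.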

Compound 4, inhibition constant: > 7000 nM
Compound 4 ended at the assay's limit; the forecaster's own chance of this, stated with the estimate: 85%; the middle value is on the limit's open side.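

In this assay compound 4 gives > 7000 nM, which is a limit and not a number. Compound 1 also stands at a limit, and the step from compound 1 to compound 4 cannot be read. The compounds shown leave open whether hydroxy in place of hydrogen on this saturated chain carbon changes the inhibition constant at all.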